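The source may report more compounds than this note shows. Statements on the series, on what has been measured and on what is new or still open speak of the compounds shown alone.

Compound 3 `CSc1nncc2c(C)nc(C)n12` is one of three close relatives examined in a functional assay for inhibition, with Homo sapiens as the target; on this read-out lower numbers stand for stronger inhibition and higher numbers for weaker inhibition. In this assay compound 3 gives > 48000 nM, which is a limit of the assay and not a number. Compound 1 `CCc1nc(C)c2cnnc(SC)n12` gives > 48000 nM in this assay, again a limit. Compound 2 `Cc1nc(C)n2c(S)nncc12` gives > 48000 nM in this assay, also a limit. So compound 3 stands nowhere that the numbers can place it.

Compound 4 `CSc1nnc(C)c2c(C)nc(C)n12` differs from compound 3 by methyl in place of hydrogen on an aromatic carbon. Two measured steps lead into compound 3, the step that the two limits leave unreadable from compound 1 to compound 3 and the step that the two limits leave unreadable from compound 2 to compound 3; neither can be sized because of the limit of > 48000 nM in this assay, at which 3 of the 3 values shown sit. Neither of them concerns a methyl on an aromatic carbon, so they bear on the change to compound 4 only by showing that the whole series sits at the limit. On that basis the step that the limit leaves unreadable from compound 3 to compound 4 is expected to be none beyond the scatter. Compound 4 is therefore estimated at 100000 nM in this assay, with a range from 30000 nM to 400000 nM, and the assay is expected most likely to report only a limit again.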

Compound 4, half-maximal inhibitory concentration: > 48000 nM
Compound 4: a limit, no number (the forecaster's own chance of this, stated with the estimate: 85%); the middle value is on the limit's open side.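

In this assay, among these compounds, compound 4 gives only a limit, as compound 3 does, so no step between compound 3 and compound 4 can be read: the limit of > 48000 nM in this assay, at which 4 of the 4 values shown sit. The compounds shown leave open whether any change to the shared core gives a measurable inhibition.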